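Swapping 4-hydroxyphenyl for 3-bromophenyl on the shared core

The source may hold more compounds than are shown below. What is called first, only, known or untested is meant among the compounds shown, and "the series" means these compounds.

Compound 1 `CC1(C)[C@H]2CC[C@]1(C)N(Cc1cn(-c3ccc(F)cc3)nn1)C(=O)C2`: 200 nM
Compound 2 `CC1(C)[C@H]2CC[C@]1(C)N(Cc1cn(-c3ccc(O)cc3)nn1)C(=O)C2`: 410 nM

Both compounds were tested in a functional assay on OVCAR-3 cells (Homo sapiens) for inhibition, read by MTT assay, with a stated time of 24 h; on this read-out lower numbers stand for stronger inhibition and higher numbers for weaker inhibition. Compound 2, at 410 nM, has the higher of the two numbers, so it is the weaker inhibitor of this pair. The next compound to consider is compound 3 `CC1(C)[C@H]2CC[C@]1(C)N(Cc1cn(-c3cccc(Br)c3)nn1)C(=O)C2`, which has not yet been measured. It has 3-bromophenyl in place of 4-hydroxyphenyl on an aromatic nitrogen.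

Among the measured compounds shown here, only one measured step bears on this change: a 2.1-fold higher number from compound 1 to compound 2 (0.31 log units; beyond the scatter). That step is modest but beyond the scatter, and it came with hydroxy in place of fluoro on an aromatic carbon. Read in reverse, it suggests that losing the hydroxy could bring a modest gain. For the measured compounds named here, no measured compound carries a bromo group, however, so this guide is only a loose one. A modest step towards a lower number is therefore expected in this assay. The estimated change is a 1.8-fold lower number from compound 2 to compound 3 (0.25 log units; within the scatter). For compound 3 the estimated value is 230 nM, with an expected range from 70 nM to 700 nM.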

Compound 3, half-maximal inhibitory concentration: 30 nM
For compound 3 the middle estimate is 7.7-fold (0.88 log units) above the measured one; measured number outside the range, below it.
By their numbers in this assay, from the lowest: compound 3; then compound 1; then compound 2.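

Within this assay, the group on the aromatic nitrogen proves able to move the number much further than the earlier pair indicated: 3-bromophenyl in place of 4-hydroxyphenyl gives a 14-fold lower number from compound 2 to compound 3 (1.14 log units; beyond the scatter), a far larger change than a 2.1-fold higher number from compound 1 to compound 2 (0.31 log units; beyond the scatter). Compound 1 also lacks the hydroxy group, yet replacing its 4-fluorophenyl with 3-bromophenyl still gives a 6.7-fold lower number from compound 1 to compound 3 (0.82 log units; beyond the scatter), so losing the hydroxy cannot be the whole story, and compound 3 is the strongest inhibitor of the three. No measurement shown here explains why this change has so large an effect.

These compounds do not show whether the gain comes from having bromine rather than fluorine or from where the halogen sits on the phenyl ring, since compound 3 differs from compound 1 in both respects. A 4-bromophenyl and a 3-fluorophenyl group would separate those two changes, while 3-chlorophenyl or 3-methylphenyl would test whether bromine itself is needed in the place it occupies in compound 3.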